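The compounds below may be only part of what the source reports. "The series", "measured", "known", "first", "only" and "open" are said of these compounds alone.

Measured compounds:
- compound 1, `CCC(C)(C)Cc1c[nH]c(CCc2ccc(-c3ccncc3)cc2)n1`: 15 nM
- compound 2, `CCC(C)(C)Cc1c[nH]c(CCc2ccc(-n3cccn3)cc2)n1`: 9 nM
- compound 3, `CCC(C)(C)Cc1c[nH]c(CCc2ccc(-c3cccc(N)n3)cc2)n1`: 3.9 nM

All three numbers come from a functional assay on HEK293 cells for agonist activity at Bombesin receptor subtype-3 (Mus musculus), read by luminescence and calcium flux, with a stated time of 10 min; on this read-out lower numbers stand for an effect already at smaller amounts and higher numbers for an effect only at larger amounts of compound. Compound 2 stands second highest of the three: its nearest neighbour is compound 1 with a 1.7-fold lower number from compound 1 to compound 2 (0.22 log units; within the scatter), and its furthest is compound 3 with a 2.3-fold lower number from compound 2 to compound 3 (0.36 log units; beyond the scatter). The step of a 3.8-fold lower number from compound 1 to compound 3 (0.59 log units; beyond the scatter) is the largest seen in the set, and it is still modest.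

Compound 4, `CCC(C)(C)Cc1c[nH]c(CCc2ccc(-n3cncn3)cc2)n1`, differs from compound 2 in one place: 1H-1,2,4-triazol-1-yl in place of 1H-pyrazol-1-yl on an aromatic carbon

For the measured compounds named here, no measured step swaps one five-membered azole for another; the steps from compound 1 to compound 2 and from compound 2 to compound 3 each exchange a ring of a different size or add a donor group, and even these move the numbers in this assay only modestly. A change that keeps ring size, attachment and the absence of donors is therefore expected to give no step beyond the scatter, with direction undetermined. The expected step is a 1.1-fold higher number from compound 2 to compound 4 (0.05 log units; within the scatter). For compound 4 the estimate in this assay is 10 nM, in the range 4 nM to 25 nM.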

Compound 4, half-maximal effective concentration: 12 nM
Beside the measured number, compound 4's estimate is 1.2-fold (0.08 log units) below it; low and high end bracket the measured number.
By their numbers in this assay, from the lowest: compound 3; then compounds 2, 4 and 1 (each within the scatter of the next).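

For the compounds shown here, replacing 1H-pyrazol-1-yl with 1H-1,2,4-triazol-1-yl is the first exchange of one five-membered aromatic ring for another at this position, and in this assay it gives a 1.3-fold higher number from compound 2 to compound 4 (0.12 log units; within the scatter) and so no resolved change. The triazole is also not separated from pyridin-4-yl, with a 1.3-fold lower number from compound 1 to compound 4 (0.10 log units; within the scatter) in the same read-out, so compounds 1, 2 and 4 all lie within the scatter of one another. Only 6-aminopyridin-2-yl stands apart from the triazole, with a 3.1-fold higher number from compound 3 to compound 4 (0.49 log units; beyond the scatter) beyond the scatter.

Still open, from the compounds shown here alone, is whether the amine on that pyridine accounts for this gap, which a plain pyridin-2-yl or a methylamino group in its place would test. The data on hand offer no explanation for the gap.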